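Replacing the pyridyl ring on the secondary amine of compound 3

The compounds below may be only part of what the source reports. "The series", "measured", "known", "first", "only" and "open" are said of these compounds alone.

Among the compounds with values here, compound 3 `c1cncc(CNCCCCN(C[C@H]2Cc3ccccc3CN2)[C@H]2CCCc3cccnc32)c1` stands lowest of the three numbers so far in a functional assay on cells for antagonist activity at C-X-C chemokine receptor type 4 (Homo sapiens), read by fluorescence and calcium flux, with stated times of 25 min and 90 s (on this read-out lower numbers stand for stronger inhibition and higher numbers for weaker inhibition), with compound 3 giving 15.3 nM. Compound 2 `c1cncc(CN(CCCCN(C[C@H]2Cc3ccccc3CN2)[C@H]2CCCc3cccnc32)Cc2cccnc2)c1` gives 471 nM and compound 1 `c1ccc(CN(CCCCN(C[C@H]2Cc3ccccc3CN2)[C@H]2CCCc3cccnc32)Cc2ccccn2)nc1` gives 664 nM in this assay. Within the data shown here, the one single-point step, a 31-fold lower number from compound 2 to compound 3 (1.49 log units; beyond the scatter), is the only measured change at the amine nitrogen that carries the (pyridin-3-yl)methyl group; it concerns loss of a whole substituent, not exchange of the ring.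

Compound 4 `c1ccc2c(c1)CN[C@@H](CN(CCCCNCC1CCOCC1)[C@H]1CCCc3cccnc31)C2` differs from compound 3 by oxan-4-yl in place of pyridin-3-yl on a saturated chain carbon bound to an amine nitrogen. Among the measured compounds shown here, no measured pair shows this exchange or any change in the ring on that chain carbon, so the step in this assay is not predicted by any number here; the large step from compound 2 to compound 3 only marks that this position responds strongly to change. A moderate move, likely toward a higher number, is expected for compound 4, as a 2.3-fold higher number from compound 3 to compound 4 (0.36 log units; beyond the scatter). Compound 4 is therefore estimated at 35 nM in this assay, within 8 nM to 150 nM.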

Compound 4, half-maximal inhibitory concentration: 52.9 nM
Compound 4: the middle estimate sits 1.5-fold (0.18 log units) below what was measured; measured number inside the range.
By their numbers in this assay, from the lowest: compound 3; then compound 4; then compounds 2 and 1 (each within the scatter of the next).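

Working from this assay, the ring on the saturated chain carbon bound to an amine nitrogen can be exchanged with only a modest shift, a 3.5-fold higher number from compound 3 to compound 4 (0.54 log units; beyond the scatter), when oxan-4-yl takes the place of pyridin-3-yl. Compound 4 thus shows that an aromatic ring is not essential here for activity to be retained, and this ring exchange moves the number much less than removing the whole substituent does in the step of a 31-fold lower number from compound 2 to compound 3 (1.49 log units; beyond the scatter). No evidence at hand accounts for the size of the step from compound 3 to compound 4.

The exchange changes ring aromaticity and the ring hetero atom together, so the two contributions remain unseparated. A phenyl or cyclohexyl ring at this place would pull them apart, and a longer chain to the ring would test the spacing.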